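Branching the alkoxy chain on a piperazine-linked pyrimidine

The source may report more compounds than this note shows. Statements on the series, on what has been measured and on what is new or still open speak of the compounds shown alone.

Compound 2 `CCCOc1cc(N2CCN(c3nc(N)c4cc(OC)c(OC)cc4n3)CC2)ncn1` was tested in an assay on brain for binding affinity to Adrenergic receptor alpha-1 (Rattus norvegicus) (on this read-out higher numbers stand for weaker inhibition and lower numbers for stronger inhibition), where compound 2 gives 0.36 nM. Within the data shown here, only one other number exists for comparison: compound 1 `COc1ccnc(N2CCN(c3nc(N)c4cc(OC)c(OC)cc4n3)CC2)n1`, which in this assay gives 0.19 nM, and the step of a 1.9-fold higher number from compound 1 to compound 2 (0.28 log units; within the scatter) lies within the scatter, so the two compounds cannot be told apart on this read-out. Compound 3 `COc1cc2nc(N3CCN(c4cc(OC(C)C)ncn4)CC3)nc(N)c2cc1OC` has not yet been measured. It differs from compound 2 by isopropyl in place of propyl on an oxygen on an aromatic ring, so the same atoms are joined differently and the chain on the oxygen merely branches. Among the measured compounds shown here, the single measured step, an exchange of one whole substituted pyrimidinyl group for another, stayed within the scatter, and this smaller rearrangement gives no reason to expect more. A step of a 1.1-fold higher number from compound 2 to compound 3 (0.05 log units; within the scatter) is therefore expected, with no direction beyond the scatter. Compound 3 is estimated at 0.4 nM, in a range from 0.15 nM to 1.1 nM.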

Compound 3, inhibition constant: 0.18 nM
Compound 3: middle estimate off by 2.2-fold (0.35 log units), on the high side; the measured number falls inside the stated range.
By their numbers in this assay, from the lowest: compounds 3, 1 and 2 (each within the scatter of the next).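

In this assay, the step from propyl to isopropyl on an oxygen on an aromatic ring is a 2.0-fold lower number from compound 2 to compound 3 (0.30 log units; within the scatter), so this small rearrangement of the same atoms does not separate the two compounds. The larger exchange of one whole substituted pyrimidinyl group for another is a 1.1-fold lower number from compound 1 to compound 3 (0.02 log units; within the scatter), and it too gives no measurable separation, leaving all three compounds indistinguishable on this read-out. Nothing given here offers an explanation for these numbers.

Still open, as far as these compounds go, is how much change this oxygen substituent can take before the number moves beyond the scatter. A longer chain such as butyl, a cyclopropyl ring on the oxygen, or an amine in place of the alkoxy group would each test that limit.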